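A benzyl swap in a series at the assay limit

The source may report more compounds than this note shows. Statements on the series, on what has been measured and on what is new or still open speak of the compounds shown alone.

In a functional assay on HT-29 cells (Homo sapiens) for antiproliferative activity, read by MTT assay, with a stated time of 72 h (a higher number here means a weaker inhibitor, a lower number a stronger inhibitor), compound 1 (`COc1cc(-c2nccn2C(C)C)cc(OC)c1OC`) gives > 100000 nM as a limit of the assay and not a number. Compound 2 (`COc1cc(-c2nccn2S(=O)(=O)c2ccccc2)cc(OC)c1OC`) gives > 100000 nM as a limit too. Compound 3 (`COc1cc(-c2nccn2S(=O)(=O)c2ccc(C)cc2)cc(OC)c1OC`) gives > 100000 nM as a limit as well. Compound 1 therefore offers no number to start from, and the whole measured set stands at one mark (the limit of > 100000 nM in this assay, at which 3 of the 3 values shown sit) with no order readable within it. Among the compounds with values here, the only measured step is a step that the two limits leave unreadable from compound 2 to compound 3 and it gives no size to carry over.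

Compound 4 (`COc1cc(-c2nccn2Cc2ccccc2)cc(OC)c1OC`) carries benzyl in place of isopropyl on an aromatic nitrogen and keeps the core of compound 1 unchanged. With compound 1 and both others at that same mark (the limit of > 100000 nM in this assay, at which 3 of the 3 values shown sit) no step beyond the scatter is expected in this assay in either direction. The estimated change is a number no higher from compound 1 to compound 4 (the limit leaves the size open) and so stays small. For compound 4 the expected value is 100000 nM with an estimated range from 30000 nM to 150000 nM and the reading may again be only a limit.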

Compound 4, half-maximal inhibitory concentration: > 100000 nM
Compound 4 gave a limit, no number; the forecaster's own chance of this, stated with the estimate: 75%; the middle value sits exactly at the limit.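

In this assay compound 1 and compound 4 each give only a limit and not a number, so the step between them cannot be read. The compounds shown leave open any order among them, as all sit at one mark: the limit of > 100000 nM in this assay, at which 4 of the 4 values shown sit.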